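A few compounds are considered here, and "the series" means these few. Any claim that something is new, unique, unknown or untested is made for them only; others in the source may bear on it.

Measured so far:
- compound 1, `O=C(/C=C/c1ccc(F)c(Cl)c1)c1ccc(B(O)O)cc1`, 22000 nM
- compound 2, `O=C(/C=C/c1ccc(B(O)O)cc1)c1ccc(Cl)c(Cl)c1`, 15000 nM
- compound 3, `O=C(O)COc1ccc(C(=O)/C=C/c2ccc(Cl)c(Cl)c2)cc1`, 15000 nM

All three numbers come from a functional assay on MCF-12A cells (Homo sapiens) for inhibition; a higher number here means a weaker inhibitor, a lower number a stronger inhibitor. Compound 1, with 22000 nM, has the largest of the three numbers, but neither neighbour is far off: compound 2 gives 15000 nM and compound 3 gives 15000 nM, and both of these gaps to compound 1 lie within the usual scatter of repeated measurements. On these numbers, then, compound 1 cannot be set apart from compound 2 or compound 3.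

The next compound, compound 4, `O=C(/C=C/c1ccc(F)c(Br)c1)c1ccc(B(O)O)cc1`, differs from compound 1 in one place only: bromo in place of chloro on an aromatic carbon. Everything else in the structure stays as it is. Within the data shown here, no pair of measured compounds shows what such an exchange of one halogen for another does in this assay, so there is no measured step to lean on. A change of one atom for a close relative of it, with no ring, no hydrogen-bond donor or acceptor and no charge added or removed, is the kind of change that usually moves the number little, if at all.

The expectation is therefore a step from compound 1 to compound 4 of a 1.1-fold lower number from compound 1 to compound 4 (0.04 log units; within the scatter), which is no movement beyond the scatter in either direction. On that basis compound 4 is estimated at 20000 nM, with a likely range from 8000 nM to 50000 nM.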

Compound 4, half-maximal inhibitory concentration: 38000 nM
For compound 4 the middle estimate is 1.9-fold (0.28 log units) below the measured one; measured number inside the range.
By their numbers in this assay, from the lowest: compounds 2, 3, 1 and 4 (each within the scatter of the next, the first and the last beyond it).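

Among these compounds, this pair gives the first measured step in the set where only one place changes, which the earlier compounds could not offer, as they differ from each other in more than one place. Measured in this assay with bromo in place of chloro on an aromatic carbon, ortho to a fluoro group and meta to a large group, the step is a 1.7-fold higher number from compound 1 to compound 4 (0.24 log units; within the scatter) and so cannot be told apart from repeat-to-repeat variation in the measurement; on this one pair, the exchange of these two halogens at this position shows no clear effect on the number, and no separate measurement is available that would explain the result in either direction.

On these data alone, this single pair says nothing about groups that are less closely related to chloro and bromo, so it remains open whether a methoxy group, an amine or a plain hydrogen on this same aromatic carbon would move the number beyond the scatter. As far as these compounds go, it is also open whether the same halogen exchange would behave alike on a different core, such as that of compound 3, where the boronic acid is replaced by a different group.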